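Series notes: aryl lactam mGlu5 modulators, compound 3

The source may report more compounds than this note shows. Statements on the series, on what has been measured and on what is new or still open speak of the compounds shown alone.

Measured so far:
compound 1 `O=C1CC(c2nc(-c3cccc(Cl)c3)no2)CN1c1ccc(Cl)c(Cl)c1` gives 460 nM
compound 2 `O=C1CC(c2nc(-c3ccc(Cl)cc3)no2)CN1c1ccc(Cl)c(Cl)c1` gives 1100 nM

Compound 1 stands lowest of the two numbers in an in vitro functional assay on HEK293-A cells for positive allosteric modulation of metabotropic glutamate receptor 5 (Homo sapiens), read by FLIPR and calcium flux; on this read-out lower numbers stand for an effect already at smaller amounts and higher numbers for an effect only at larger amounts of compound; the nearest is compound 2, reached by a 2.4-fold higher number from compound 1 to compound 2 (0.38 log units; beyond the scatter), a change of 4-chlorophenyl in place of 3-chlorophenyl on an aromatic carbon.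

Compound 3 `Cc1cccc(N2CC(c3nc(-c4cccc(Cl)c4)no3)CC2=O)c1` has not been measured. It differs from compound 1 by 3-methylphenyl in place of 3,4-dichlorophenyl on an amide-type nitrogen in a ring: 3-methylphenyl in place of 3,4-dichlorophenyl on the amide-type nitrogen in the ring of the shared core. Among the measured compounds shown here, no measured step touches this part of the molecule; the only step known, a 2.4-fold higher number from compound 1 to compound 2 (0.38 log units; beyond the scatter), concerns the other aromatic ring and was modest. For the measured compounds named here, the change in compound 3 removes both chlorines and adds a methyl, so no direct reference exists, and the expectation is drawn only from the size of the one step seen. A loss of some size is expected for compound 3, a 3.3-fold higher number from compound 1 to compound 3 (0.51 log units; beyond the scatter), with wide uncertainty. Compound 3 is estimated at 1500 nM, within a range of 500 nM to 5000 nM.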

Compound 3, half-maximal effective concentration: > 10000 nM
Compound 3 gave a limit, no number; the forecaster's own chance of this, stated with the estimate: 20%; middle value at least 6.6-fold (0.82 log units) from the limit.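

In this assay, among the compounds shown here, the group on the amide-type nitrogen in a ring of the shared core carries far more weight than the earlier compounds could show: an at least 21-fold higher number from compound 1 to compound 3 (1.33 log units; beyond the scatter), against only a 2.4-fold higher number from compound 1 to compound 2 (0.38 log units; beyond the scatter) for the change on the other aromatic ring. The response measured for compound 1 therefore depends strongly on what sits at this position, and 3-methylphenyl does not serve as a replacement for 3,4-dichlorophenyl here, even though the two groups differ by just one heavy atom and both are six-membered aromatic rings of carbon only. For compound 3 the result is a limit of the assay and not a number: the limit of > 10000 nM in this assay, at which 1 of the 3 values shown sits.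

The change removes two chlorine atoms and brings in a methyl group in a single step, so the compounds shown do not separate the loss of either chlorine from the entry of the methyl. From the compounds shown here alone, a 3-chlorophenyl, a 4-chlorophenyl or an unsubstituted phenyl on this nitrogen would help to separate them, and how a methoxy group or a nitrile on that ring would read remains open.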